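Compound 3 to compound 4: amide replaced by carboxy

The source may report more compounds than this note shows. Statements on the series, on what has been measured and on what is new or still open speak of the compounds shown alone.

In a physicochemical assay for solubility, read by HPLC, using the shake flask method, with a stated time of 2 h, at pH 2 (a lower number here means a less soluble compound, a higher number a more soluble compound), compound 3 `Nc1ncc(-c2ccc(C(=O)N3CC[C@@H](O)C3)cc2)nc1-c1ccc(C(F)(F)F)cc1` gives 103000 nM, within the scatter of compound 1 `Nc1ncc(-c2ccc(C(=O)N3CC(O)C3)cc2)nc1-c1ccc(C(F)(F)F)cc1` at 110000 nM and compound 2 `Nc1ncc(-c2ccc(C(=O)N3CCC(O)C3)cc2)nc1-c1ccc(C(F)(F)F)cc1` at 129000 nM. Compound 4 `Nc1ncc(-c2ccc(C(=O)O)cc2)nc1-c1ccc(C(F)(F)F)cc1` carries hydroxy in place of 3-hydroxypyrrolidin-1-yl on a carbonyl carbon. The measured steps closest to this change are a 1.2-fold higher number from compound 1 to compound 2 (0.07 log units; within the scatter), a 1.1-fold lower number from compound 1 to compound 3 (0.03 log units; within the scatter) and a 1.3-fold lower number from compound 2 to compound 3 (0.10 log units; within the scatter), all within the scatter. Each of them keeps a hydroxy-bearing ring on the carbonyl carbon, so none of them samples the loss of that ring. A lower number in this assay is expected, but with wide uncertainty. The expected step is a 13-fold lower number from compound 3 to compound 4 (1.11 log units; beyond the scatter). For compound 4 the estimated value is 8000 nM, with a range of 1000 nM to 60000 nM.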

Compound 4, solubility: < 5000 nM
Compound 4 was reported as a limit; the forecaster's own chance of this, stated with the estimate: 15%; at least 1.6-fold (0.20 log units) between middle value and limit.
By their numbers in this assay, from the lowest: compounds 3, 1 and 2 (each within the scatter of the next). At a limit, below all of these: compound 4.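

In this assay compound 4 stands only as a limit, < 5000 nM. Hydroxy on the carbonyl carbon gives the first steps in this series beyond the scatter: an at least 20-fold lower number from compound 3 to compound 4 (1.31 log units; beyond the scatter), an at least 25-fold lower number from compound 2 to compound 4 (1.41 log units; beyond the scatter) and an at least 22-fold lower number from compound 1 to compound 4 (1.34 log units; beyond the scatter). Changing ring size or drawn configuration among compounds 1, 2 and 3 left all steps within the scatter, so only the replacement of the ring amide by the carboxy group separates the values at this position.

On these data alone, the exact size of these steps stays open behind the limit. A primary amide on the same carbonyl carbon would help separate loss of the hydroxy-bearing ring from gain of the carboxylic acid.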